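The source may report more compounds than this note shows. Statements on the series, on what has been measured and on what is new or still open speak of the compounds shown alone.

Measured so far in a functional assay on CCRF-CEM cells (Homo sapiens) for cytotoxicity, read by MTT assay, with a stated time of 72 h; on this read-out higher numbers stand for lower toxicity in this test and lower numbers for higher toxicity in this test:
compound 1, `CCCCCCOC(=O)Nc1ccc([Se]C#N)cc1`: 72700 nM
compound 2, `CCOC(=O)Nc1ccc([Se]C#N)cc1`: 68800 nM

In this assay, among the compounds with values here, compound 2 gives 68800 nM, the lower of the two numbers, but the only step to it, a 1.1-fold lower number from compound 1 to compound 2 (0.02 log units; within the scatter), shows the two compounds cannot be told apart on this read-out. Compound 3, `N#C[Se]c1ccc(NC(=O)OCc2ccccc2)cc1`, has not been measured in this assay. It differs from compound 2 by phenyl in place of methyl on a saturated chain carbon bound to an oxygen next to a carbonyl group. Within the data shown here, the one measured step that bears on this part of the molecule is a 1.1-fold lower number from compound 1 to compound 2 (0.02 log units; within the scatter), a change of the chain on the saturated carbon bound to the oxygen next to a carbonyl group, which left the number essentially where it was. The new group is a ring rather than a chain, so that precedent is only partial, yet nothing measured points to a step beyond the scatter in this assay. Compound 3 is therefore expected at 55000 nM (20000 nM to 150000 nM), an expected step of a 1.3-fold lower number from compound 2 to compound 3 (0.10 log units; within the scatter).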

Compound 3, concentration lethal to 50% of the cells: 73700 nM
The estimate for compound 3 lay 1.3-fold (0.13 log units) below the measured number, and the stated range covers the measured number.
By their numbers in this assay, from the lowest: compounds 2, 1 and 3 (each within the scatter of the next).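

In this assay, phenyl in place of methyl gives a 1.1-fold higher number from compound 2 to compound 3 (0.03 log units; within the scatter) and phenyl in place of pentyl gives a 1.0-fold higher number from compound 1 to compound 3 (0.01 log units; within the scatter). The earlier step covered only a change of chain, whereas these two show that an aromatic ring on the saturated chain carbon bound to an oxygen next to a carbonyl group also leaves compound 1, compound 2 and compound 3 indistinguishable on this read-out. No measurement offered here accounts for this lack of separation.

On these data alone, whether an amine or a carboxylic acid at this place would produce a step beyond the scatter remains open, as does the outcome of putting either group on the phenyl ring. The compounds shown also leave open what a change elsewhere in the shared core, such as replacing the nitrile, would do.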